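A few compounds are considered here, and "the series" means these few. Any claim that something is new, unique, unknown or untested is made for them only; others in the source may bear on it.

Measured compounds in a functional assay on BJAB cells (Homo sapiens) for antiproliferative activity, with a stated time of 4 days; on this read-out lower numbers stand for an effect already at smaller amounts and higher numbers for an effect only at larger amounts of compound:
Compound 1, `Cc1nn(-c2nc(-c3ccc(Cl)c(Cl)c3)c(SC(C)C)s2)c(C(=O)O)c1-c1ccncc1`: 5900 nM
Compound 2, `Cc1nn(-c2nc(-c3ccc(Cl)c(Cl)c3)c(SC(C)C)s2)c(C(=O)O)c1-c1ccc(C(F)(F)F)cc1`: 3500 nM

Compound 2 shows the lower of the two numbers, but the step of a 1.7-fold lower number from compound 1 to compound 2 (0.23 log units; within the scatter) does not reach beyond the scatter, so compound 1 and compound 2 cannot be told apart on these data. Compound 3, `COc1ccc(C)cc1-c1c(C)nn(-c2nc(-c3ccc(Cl)c(Cl)c3)c(SC(C)C)s2)c1C(=O)O`, differs from compound 2 in one place: 2-methoxy-5-methylphenyl in place of 4-(trifluoromethyl)phenyl on an aromatic carbon. Within the data shown here, only one measured step touches this position, a 1.7-fold lower number from compound 1 to compound 2 (0.23 log units; within the scatter), and it exchanged one aryl group for another at the same place without moving the number beyond the scatter. The exchange leading to compound 3 is again a change of the aryl group at that position, so no step beyond the scatter is expected in this assay. Compound 3 is therefore estimated at 4000 nM, with a range from 1500 nM to 12000 nM, which means an expected step of a 1.1-fold higher number from compound 2 to compound 3 (0.06 log units; within the scatter).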

Compound 3, half-maximal effective concentration: 9500 nM
Compound 3: middle estimate off by 2.4-fold (0.38 log units), on the low side; measured number inside the range.
By their numbers in this assay, from the lowest: compounds 2, 1 and 3 (each within the scatter of the next, the first and the last beyond it).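

In this assay, this position now shows its first step beyond the scatter, though a modest one (a 2.7-fold higher number from compound 2 to compound 3 (0.43 log units; beyond the scatter)), when 2-methoxy-5-methylphenyl replaces 4-(trifluoromethyl)phenyl. Among these compounds, the aryl group here can therefore shift the number, yet the same entering group leaves it within the scatter when it replaces pyridin-4-yl (a 1.6-fold higher number from compound 1 to compound 3 (0.21 log units; within the scatter)), so only the pair of compound 2 and compound 3 can be told apart. Nothing available accounts for this step.

The compounds shown leave open whether the methoxy or the methyl group of the entering aryl goes with the step, as the two enter together. As far as these compounds go, how an unsubstituted phenyl or an amine such as piperidin-4-yl would read at this place also remains open.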